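Moving the chlorine on the pendant phenyl of compound 2

The source may report more compounds than this note shows. Statements on the series, on what has been measured and on what is new or still open speak of the compounds shown alone.

Compound 1 `CN1CCN(c2nc(-c3cccc(O)c3)nc3c2ncn3C)CC1` gives 47.8% in an assay on cells for displacement of a labelled ligand from adenosine receptor A2b (Homo sapiens), read by scintillation counting and radioligand binding, with a stated time of 30 min, tested at 10 uM; a higher number here means more inhibition at the concentration tested (going by the name of the read-out), a lower number less inhibition.
Compound 2 `CN1CCN(c2nc(-c3cccc(Cl)c3)nc3[nH]cnc23)CC1` gives 29.9% in this assay.
Compound 3 `CN1CCN(c2nc(-c3cccc(Cl)c3)nc3c2ncn3C)CC1` gives 19.2% in this assay.

Compound 2 stands second highest of the three numbers. For the measured compounds named here, its nearest neighbour is compound 3, with a number 10.7 percentage points lower from compound 2 to compound 3 (beyond the scatter), and the furthest is compound 1, whose number lies above that of compound 2 by more than the scatter; no single-point step joins compound 1 and compound 2.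

Compound 4 `CN1CCN(c2nc(-c3ccc(Cl)cc3)nc3[nH]cnc23)CC1` differs from compound 2 in one place: 4-chlorophenyl in place of 3-chlorophenyl on an aromatic carbon. Neither measured step compares a 3-chlorophenyl with a 4-chlorophenyl. The step of a number 28.6 percentage points lower from compound 1 to compound 3 (beyond the scatter) exchanges the group on the phenyl, and the step of a number 10.7 percentage points lower from compound 2 to compound 3 (beyond the scatter) alters the aromatic nitrogen of the shared core; both were modest and downward, but neither bears on this change. Going by the values given here, with no comparable step in hand, the expectation for this assay is a step within the scatter, with a wide range to either side.

Compound 4 is therefore expected to give 30%, between 10% and 50%. The expected step is a number 0.1 percentage points higher from compound 2 to compound 4 (within the scatter).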

Compound 4, a percentage reported as inhibition, at one concentration (the size of the read-out at that concentration, not a potency): 6.2%
Compound 4: middle estimate off by 23.8 percentage points, on the high side, and the stated range ends above it.
By their numbers in this assay, from the lowest: compound 4; then compound 3; then compound 2; then compound 1.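

In this assay, the place of the chlorine on the pendant phenyl matters by itself: 4-chlorophenyl in place of 3-chlorophenyl gives a number 23.7 percentage points lower from compound 2 to compound 4 (beyond the scatter) while the atom count stays the same. For the compounds shown here, the earlier steps changed the group on the phenyl or the aromatic nitrogen of the shared core, so this is the first step to change only how the same atoms are joined. No measurement shown here accounts for the drop in the number at this position.

As far as these compounds go, whether the same drop appears on the methylated core of compound 3 remains open. It is also unknown whether a 4-hydroxyphenyl or 4-aminophenyl group would lower the number as 4-chlorophenyl does.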